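The source may hold more compounds than are shown below. What is called first, only, known or untested is meant among the compounds shown, and "the series" means these compounds.

- Compound 1 `COc1cc(C2CN(C(=O)c3cc(OCCO)ccn3)C2)ccc1OCc1ccc(C2CC2)cc1` gives 800 nM
- Compound 2 `COc1cc(C2CN(C(=O)c3cc(OC[C@H](O)CO)ccn3)C2)ccc1OCc1ccc(C2CC2)cc1` gives 2700 nM
- Compound 3 `COc1cc(C2CN(C(=O)c3cc(OC[C@@H](O)CO)ccn3)C2)ccc1OCc1ccc(C2CC2)cc1` gives 3100 nM

These three values come from a physicochemical assay for solubility, in phosphate buffer, at pH 7.2 (on this read-out lower numbers stand for lower solubility and higher numbers for higher solubility), and place compound 3 level with compound 2, the gap being a 1.1-fold higher number from compound 2 to compound 3 (0.06 log units; within the scatter). The evidence on that pair is the fact that compounds 2 and 3 differ only in the configuration as drawn. Compound 3 stands clear of compound 1, with a 3.9-fold higher number from compound 1 to compound 3 (0.59 log units; beyond the scatter), and the matching step to its mirror partner is a 3.4-fold higher number from compound 1 to compound 2 (0.53 log units; beyond the scatter).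

Compound 4 `COc1cc(C2CN(C(=O)c3cc(OCCCC(=O)O)ccn3)C2)ccc1OCc1ccc(C2CC2)cc1` has yet to be measured. It carries 2-carboxyethyl in place of 1,2-dihydroxyethyl on a saturated chain carbon bound to an oxygen on an aromatic ring. Only the two steps from compound 1 touch this chain. Both were modest, both added hydroxymethyl, and neither puts 2-carboxyethyl in place, so they are a loose guide to size at best. For the measured compounds named here, the expected change in this assay is a 3.2-fold higher number from compound 3 to compound 4 (0.51 log units; beyond the scatter), an upward step estimated to be larger than those modest ones, and held with wide margins since no measured step tests this group. For compound 4 the estimated value is 10000 nM, with an expected range from 1500 nM to 60000 nM.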

Compound 4, solubility: 1100 nM
For compound 4 the middle estimate is 9.1-fold (0.96 log units) above the measured one; the whole stated range lies above it.
By their numbers in this assay, from the lowest: compounds 1 and 4 (each within the scatter of the next); then compounds 2 and 3 (each within the scatter of the next).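

For the compounds shown here, replacing 1,2-dihydroxyethyl with 2-carboxyethyl, on a saturated chain carbon bound to an oxygen on an aromatic ring, gave the first downward steps at this position in this assay: a 2.8-fold lower number from compound 3 to compound 4 (0.45 log units; beyond the scatter), and a 2.5-fold lower number from compound 2 to compound 4 (0.39 log units; beyond the scatter). Against compound 1, the same position shows no readable difference, with a 1.4-fold higher number from compound 1 to compound 4 (0.14 log units; within the scatter), so the 3-carboxypropoxy chain gives up the gain seen with the two 2,3-dihydroxypropoxy chains even though it keeps a polar-looking end in name only, and a change at this position does not always raise the number. Nothing in the data gives a cause for these steps.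

The shown compounds hold only one chain ending in a carboxylic acid, so it remains open whether a shorter or longer acid chain would read differently in this assay. Going by these compounds, what a terminal amine or a primary amide on the same chain would give there also remains open, as does whether either could match compound 2 and compound 3.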